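This account rests on a few compounds, and the source may have more. Where it says the series, first, only, none or still open, it means among the compounds named here.

Compound 1 `CCOC(=O)/C=C/c1ccncc1-c1ccc2[nH]ccc2c1` — in a functional assay on KB cells (Homo sapiens) for inhibition, read by sulforhodamine B assay, with a stated time of 72 h (on this read-out lower numbers stand for stronger inhibition of growth and higher numbers for weaker inhibition of growth), compound 1 gives > 10000 nM, a limit of the assay.
Compound 2 `COC1CN(C(=O)/C=C/c2ccncc2-c2ccc3ccccc3c2)C1` — compound 2 gives > 10000 nM, again a limit of the assay.
Compound 3 `CNC(=O)/C=C/c1ccncc1-c1ccc2[nH]ccc2c1` — compound 3 gives > 10000 nM, likewise a limit of the assay.

Compound 2 therefore stands at the limit of this assay: its result is a boundary, not a number, and the same holds for every other value shown, as the limit of > 10000 nM in this assay, at which 3 of the 3 values shown sit, records. Compound 4 `CNC(=O)/C=C/c1ccncc1-c1ccc2ccccc2c1` differs from compound 2 in one place: methylamino in place of 3-methoxyazetidin-1-yl on a carbonyl carbon. Within the data shown here, the only measured step between compounds differing in one place is a step that the two limits leave unreadable from compound 1 to compound 3, also a change on the carbonyl carbon, but with both ends at the limit its size cannot be read. Among the measured compounds shown here, no measured step thus tells in which direction, if at all, this change moves growth inhibition. Because the limit of > 10000 nM in this assay, at which 3 of the 3 values shown sit, puts every value at the boundary, compound 4 is expected to give 20000 nM, within 5000 nM to 100000 nM. The expected step that the limit leaves unreadable from compound 2 to compound 4 is estimated as none beyond the scatter, with the result most likely once more a limit.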

Compound 4, concentration for 50% growth inhibition: > 10000 nM
Compound 4 was reported as a limit; the forecaster's own chance of this, stated with the estimate: 85%; the middle value is on the limit's open side.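

In this assay compound 2 and compound 4 both stand at a limit, so no size can be read for the change between them: the limit of > 10000 nM in this assay, at which 4 of the 4 values shown sit.

The compounds shown leave open whether any change on the carbonyl carbon moves growth inhibition at all.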